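The compounds below may be only part of what the source reports. "The series", "measured", "known", "first", "only" and "open" are said of these compounds alone.

Three compounds share one core and differ only in the group attached to an aromatic carbon. In a functional assay (aorta) with Rattus norvegicus as the target (a higher number here means a more potent compound, by a factor of ten per unit of this negative logarithm, a lower number a less potent compound), compound 1 `CC1(C)C=C(n2ccccc2=O)c2cc(C(=O)c3ccc(O)cc3)ccc2O1` gives 6.65. Compound 2 `CC1(C)C=C(n2ccccc2=O)c2cc(C(=N)NO)ccc2O1` gives 5.99 in this assay, and compound 3 `CC1(C)C=C(n2ccccc2=O)c2cc(OC(=O)Nc3ccccc3C(F)(F)F)ccc2O1` gives 5.58. Compound 2 therefore stands second highest of the three numbers, closer to compound 3 than to compound 1. Going by the values given here, the only measured step that changes one place is a number 0.66 log units lower from compound 1 to compound 2 (beyond the scatter), where a small chain took the place of a whole aromatic group.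

Compound 4 `CC1(C)C=C(n2ccccc2=O)c2cc(C(=N)S)ccc2O1` has not yet been measured. It differs from compound 2 in one place: sulfanyl in place of hydroxyamino on a carbon with a double bond to nitrogen. Among the compounds with values here, no measured step alters this small chain itself, so there is no direct guide; the exchange of the larger group in a number 0.66 log units lower from compound 1 to compound 2 (beyond the scatter) is far bigger than this one. The expected step is accordingly a number 0.19 log units lower from compound 2 to compound 4 (within the scatter), a shift of modest size at most, with the direction uncertain. Compound 4 is expected to give 5.8 in this assay, within 5.2 to 6.4.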

Compound 4, logarithm of the reciprocal of the active concentration, log(1/C): 6.21
Beside the measured number, compound 4's estimate is 0.41 log units below it; the range from low to high includes it.
By their numbers in this assay, from the lowest: compound 3; then compounds 2 and 4 (each within the scatter of the next); then compound 1.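

In this assay the step of a number 0.22 log units higher from compound 2 to compound 4 (within the scatter) means that the two compounds cannot be told apart, so on a carbon with a double bond to nitrogen, sulfanyl can stand in place of hydroxyamino with no measurable consequence here. The step of a number 0.44 log units lower from compound 1 to compound 4 (beyond the scatter) sits alongside the earlier step of a number 0.66 log units lower from compound 1 to compound 2 (beyond the scatter) and shows that a second small chain on the aromatic carbon also falls short of the larger group it replaces. No accompanying measurement offers a reason for either result.

From the compounds shown here alone, it remains open whether an amine or a methyl group on that same carbon would give a similar number. Also open, going by these compounds, is whether a longer chain on the aromatic carbon would come closer to compound 1.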